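This account rests on a few compounds, and the source may have more. Where it says the series, first, only, none or still open, it means among the compounds named here.

Compound 1 `Cc1c(C(=O)N/N=C\c2ccncc2)oc2cccc(O)c12` is the starting point of this step. In a functional assay on PC-3 cells (Homo sapiens) for inhibition (a lower number here means a stronger inhibitor, a higher number a weaker inhibitor), compound 1 gives >= 40000 nM, which is a limit of the assay rather than a measured number. Compound 1 therefore stands at the limit of >= 40000 nM in this assay, at which 1 of the 2 values shown sits. Among the measured compounds shown here, a second compound in the same set, compound 2 `Cc1c(C(=O)N/N=C\c2cc(Cl)cc(Cl)c2O)oc2cccc(O)c12`, carries a hydroxylated aryl group in place of the pyridine and gives 9590 nM in this assay; it differs from compound 1 in more than one place, so its value shows only that a measurable number is reachable with this shared core. The unmeasured compound 3 `Cc1c(C(=O)N/N=C\c2c(O)cccc2F)oc2cccc(O)c12` differs from compound 1 by a single change: 2-fluoro-6-hydroxyphenyl in place of pyridin-4-yl on a carbon with a double bond to nitrogen. For the measured compounds named here, no step between two measured compounds is known, so the expected size rests on the two values shown. The change is expected to move this assay toward stronger inhibition, with the step estimated at an at least 2.6-fold lower number from compound 1 to compound 3 (0.42 log units; beyond the scatter). Compound 3 is expected to give about 15000 nM, within 5000 nM to 40000 nM.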

Compound 3, half-maximal inhibitory concentration: 8050 nM
Estimate against measurement, compound 3: 1.9-fold (0.27 log units) above; measured number inside the range.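

In this assay, replacing the pyridin-4-yl group with 2-fluoro-6-hydroxyphenyl gives an at least 4.9-fold lower number from compound 1 to compound 3 (0.69 log units; beyond the scatter), so a single change at this position is enough to reach a measurable inhibition value. Compound 2 differs from compound 1 in more than one place, so this is the only pair shown that ties the gain to one change. The true size of the step remains unknown because compound 1 stands at a limit of the assay rather than at a number: the limit of >= 40000 nM in this assay, at which 1 of the 3 values shown sits.

As far as these compounds go, it remains open whether the hydroxyl, the fluorine or the carbon-only ring accounts for the step; a plain phenyl or a 2-hydroxyphenyl group at this place would help separate them. Whether a phenyl ring bearing an amine or a carboxylic acid would also give a lower number is open too.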